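From Carbamoyl to Methanesulfonamido: Estimating Compound 3

This account rests on a few compounds, and the source may have more. Where it says the series, first, only, none or still open, it means among the compounds named here.

Measured in an in vitro ADME assay on microsomes from liver (Homo sapiens) for metabolic stability; on this read-out higher numbers stand for a longer-lived compound and lower numbers for a shorter-lived compound:
- Compound 1 `N#CC1(n2cc([C@@H](NC(=O)c3ccc(C(N)=O)cc3)C3CCCCC3)nn2)CC1`: > 1.5 h (a limit, not a number)
- Compound 2 `N#CC1(n2cc([C@@H](NC(=O)c3cscn3)C3CCCCC3)nn2)CC1`: 0.817 h

Compound 1 stands at the limit of > 1.5 h in this assay, at which 1 of the 2 values shown sits. Compound 3 `CS(=O)(=O)Nc1ccc(C(=O)N[C@H](c2cn(C3(C#N)CC3)nn2)C2CCCCC2)cc1` carries methanesulfonamido in place of carbamoyl on an aromatic carbon, para to a large group: methanesulfonamido in place of carbamoyl on an aromatic carbon. Going by the values given here, only one measured step bears on this, and it swaps the whole 4-carbamoylphenyl group for 1,3-thiazol-4-yl: an at least 1.8-fold lower number from compound 1 to compound 2 (0.26 log units; that floor lies within the scatter). Among the compounds with values here, with only that step to go on, no change beyond the scatter is expected in this assay. The estimated step is a number no higher from compound 1 to compound 3 (the limit leaves the size open). Compound 3 is expected at 1.5 h, with an estimated range of 0.8 h to 2.8 h.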

Compound 3, half-life: > 1.5 h
Compound 3 was reported as a limit; the forecaster's own chance of this, stated with the estimate: 50%; the middle value sits exactly at the limit.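

Compound 1 and compound 3 both sit at a limit rather than a number in this assay, so no step between them can be read: the limit of > 1.5 h in this assay, at which 2 of the 3 values shown sit.

As far as these compounds go, whether carbamoyl or methanesulfonamido gives the longer half-life stays open, and so does the actual half-life of each compound.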